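The source may report more compounds than this note shows. Statements on the series, on what has been measured and on what is new or still open speak of the compounds shown alone.

Measured so far in a physicochemical assay for solubility, read by HPLC, in phosphate buffer, measured as kinetic solubility, at pH 7.4; a higher number here means a more soluble compound, a lower number a less soluble compound:

compound 1 `CCC(=O)c1cc(-c2ccccc2Cl)n(-c2ccc(S(N)(=O)=O)cc2)c1C` gives 38200 nM
compound 2 `CCOC(=O)c1cc(-c2ccccc2Cl)n(-c2ccc(S(N)(=O)=O)cc2)c1C` gives 13700 nM
compound 3 `CCC(=O)c1cc(-c2ccc(F)cc2)n(-c2ccc(S(N)(=O)=O)cc2)c1` gives 63000 nM

Compound 1 and compound 2 share a core and differ at a single point: ethoxy in place of ethyl on a carbonyl carbon. That change produced a step of a 2.8-fold lower number from compound 1 to compound 2 (0.45 log units; beyond the scatter) in this assay. Compound 3 carries a different core; how it differs from compound 1 is not broken down here. The value of compound 3 and that of compound 1 lie within the usual scatter of each other, so nothing is said here about which of the two stands higher; the value of compound 2 lies beyond the scatter below both.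

Compound 4 `CCOC(=O)c1cc(-c2ccc(F)cc2)n(-c2ccc(S(N)(=O)=O)cc2)c1` has not yet been measured. It stands to compound 3 as compound 2 stands to compound 1: ethoxy in place of ethyl on a carbonyl carbon. The place is described in the same words for both pairs, so this is the same change made on a different core. Among the measured compounds shown here, with only one earlier instance of the change there is no way to tell whether its size depends on the core; the expectation therefore rests on the single step of a 2.8-fold lower number from compound 1 to compound 2 (0.45 log units; beyond the scatter) and on the starting value of compound 3, 63000 nM. For compound 4 in this assay a step of a 2.7-fold lower number from compound 3 to compound 4 (0.44 log units; beyond the scatter) is expected. The estimate for compound 4 is 23000 nM, with a range from 11000 nM to 48000 nM.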

Compound 4, solubility: 36400 nM
Estimate against measurement, compound 4: 1.6-fold (0.20 log units) below, within the range that was stated.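

In this assay, ethoxy in place of ethyl on a carbonyl carbon gives a step on the core of compound 3 (a 1.7-fold lower number from compound 3 to compound 4 (0.24 log units; within the scatter)) that stays within the usual scatter, whereas the same change on the core of compound 1 gave a step (a 2.8-fold lower number from compound 1 to compound 2 (0.45 log units; beyond the scatter)) that stands beyond it. The change thus carries to the second core without a firm reading: this pair neither confirms a real step there nor rules one out, and two pairs alone cannot show whether the size of the step depends on the core. No measurement at hand bears on what lies behind this result.

The compounds shown hold only ethyl and ethoxy on the carbonyl carbon, so it remains open how an amine forming an amide, a carboxylic acid, or a longer chain such as propoxy would read in this assay on either core. As far as these compounds go, it also remains open which of the differences between the two cores goes with the difference in how the two steps read, and a further matched pair on a third core would be needed to say whether the step holds across the series.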